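This account rests on a few compounds, and the source may have more. Where it says the series, first, only, none or still open, it means among the compounds named here.

Compound 1 `C=C1CC[C@H]2[C@@](C)(CCC(=O)N[C@@]2(C)COC(=O)c2cccnc2)[C@@H]1/C=C/C1=CCOC1=O`: > 50000 nM
Compound 2 `C=C1CC[C@H]2[C@@](C)(CCC(=O)N[C@@]2(C)COC(=O)[C@H](N)CC(C)C)[C@@H]1/C=C/C1=CCOC1=O`: > 50000 nM
Compound 3 `C=C1CC[C@H]2[C@@](C)(CC[C@@H](OC(=O)c3cccnc3)[C@@]2(C)NC=O)[C@@H]1/C=C/C1=CCOC1=O`: > 50000 nM

In a functional assay on RAW264.7 cells (Mus musculus) for inhibition, read by Griess assay, with stated times of 3 h and 24 h (a lower number here means a stronger inhibitor, a higher number a weaker inhibitor), compound 3 gives > 50000 nM, which is a limit and not a number. All three compounds therefore stand at one mark, (the limit of > 50000 nM in this assay, at which 3 of the 3 values shown sit), and no order among them can be read.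

Compound 4 `C=C1CC[C@H]2[C@@](C)(CC[C@@H](OC(=O)CNC)[C@@]2(C)NC=O)[C@@H]1/C=C/C1=CCOC1=O` keeps the core of compound 3 and carries (methylamino)methyl in place of pyridin-3-yl on a carbonyl carbon.

Among the measured compounds shown here, the only measured step of a similar kind is a step that the two limits leave unreadable from compound 1 to compound 2. There, too, pyridin-3-yl leaves a carbonyl carbon and a group with no ring and with a nitrogen enters, yet both ends stay at the limit. It gives no size to carry over and no sign of a gain in this assay.

The expected change is therefore none beyond the scatter, in neither direction: a number no higher from compound 3 to compound 4 (the limit leaves the size open). For compound 4 the estimated value is 50000 nM, with an expected range of 20000 nM to 100000 nM.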

Compound 4, half-maximal inhibitory concentration: > 50000 nM
Compound 4: a limit, no number; the forecaster's own chance of this, stated with the estimate: 75%; the middle value lies on the limit itself.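

No step can be read from compound 3 to compound 4, because each result is a limit and not a number, and all four compounds share one mark: the limit of > 50000 nM in this assay, at which 4 of the 4 values shown sit.

The compounds shown leave open how strongly any of them inhibits, and whether changing the group on a carbonyl carbon shifts the result at all.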